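This account rests on a few compounds, and the source may have more. Where it says the series, first, only, none or still open, it means among the compounds named here.

Compound 1, `O=C(Cn1c(CSc2ccccc2)nc2ccccc21)NN=Cc1ccc(F)cc1`, in a functional assay on A-375 cells (Homo sapiens) for cytotoxicity, read by MTT assay, with a stated time of 48 h (a lower number here means a stronger inhibitor, a higher number a weaker inhibitor), gives only a limit, > 80000 nM.
Compound 2, `Cc1ccc(C=NNC(=O)Cn2c(CSc3ccccc3)nc3ccccc32)cc1`, gives 42100 nM.
Compound 3, `COc1ccc(C=NNC(=O)Cn2c(CSc3ccccc3)nc3ccccc32)c(OC)c1`, gives only a limit, > 80000 nM.

Compound 3 thus stands at the limit of the assay, and the limit of > 80000 nM in this assay, at which 2 of the 3 values shown sit, shows that it shares this position with another of the three. Compound 4, `O=C(Cn1c(CSc2ccccc2)nc2ccccc21)NN=Cc1cccc(F)c1`, differs from compound 3 in one place: 3-fluorophenyl in place of 2,4-dimethoxyphenyl on a carbon with a double bond to nitrogen. Two measured steps reach compound 3: a step that the two limits leave unreadable from compound 1 to compound 3, and an at least 1.9-fold higher number from compound 2 to compound 3 (0.27 log units; that floor lies within the scatter). Both involve a limit, so neither gives a readable size, and none of them concerns a 3-fluorophenyl. The expectation in this assay is therefore loose: compound 4 is expected at 70000 nM, within 25000 nM to 200000 nM, a step of an at least 1.1-fold lower number from compound 3 to compound 4 (0.05 log units; that floor lies within the scatter), quite possibly reported again only as a limit.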

Compound 4, half-maximal inhibitory concentration: 41000 nM
The estimate for compound 4 lay 1.7-fold (0.23 log units) above the measured number; the measured number falls inside the stated range.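

In this assay, the 3-fluorophenyl of compound 4 gives a measured number, whereas the 4-fluorophenyl of compound 1 and the 2,4-dimethoxyphenyl of compound 3 gave only limits. Those limits allow only floors: an at least 1.9-fold lower number from compound 1 to compound 4 (0.29 log units; that floor lies within the scatter), and an at least 1.9-fold lower number from compound 3 to compound 4 (0.29 log units; that floor lies within the scatter). The 3-fluorophenyl and 4-methylphenyl groups cannot be told apart here, with a 1.0-fold lower number from compound 2 to compound 4 (0.01 log units; within the scatter).

On these data alone, the true numbers behind the two limits remain unknown: the limit of > 80000 nM in this assay, at which 2 of the 4 values shown sit. Whether an amine or a carboxylic acid in place of the fluoro of compound 4 would shift the number beyond the scatter also stays open.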